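Changing One Side Group on a Growth-Inhibiting Compound

The compounds below may be only part of what the source reports. "The series", "measured", "known", "first", "only" and "open" are said of these compounds alone.

Compound 1 `Cc1ccccc1Nc1nc(Nc2cc(Cl)ccn2)ncc1Cl` gives 41500 nM
Compound 2 `COc1ccc(CNc2nc(Nc3ccc(N4CCN(C)CC4)cn3)ncc2Cl)cc1` gives 12900 nM

In an ADME assay on L02 cells (Homo sapiens) for inhibition, read by CCK-8 assay, with a stated time of 48 h (on this read-out lower numbers stand for stronger inhibition of growth and higher numbers for weaker inhibition of growth), compound 2 has the lower of the two numbers at 12900 nM and compound 1 sits higher at 41500 nM by more than the usual scatter of repeated measurements.

The next compound to be measured is compound 3 `CC(C)c1cccc(Nc2nc(Nc3ccc(N4CCN(C)CC4)cn3)ncc2Cl)c1` in the same test. It carries 3-isopropylphenyl in place of 4-methoxybenzyl on a nitrogen on an aromatic ring and the rest of compound 2 stays unchanged.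

For the measured compounds named here, no two measured compounds differ in one place alone, so no measured step shows what a swap like this does. The expectation therefore starts from compound 2 at 12900 nM and allows only a small shift toward a lower number in this assay with nothing beyond the scatter. The expected change is a 1.3-fold lower number from compound 2 to compound 3 (0.11 log units; within the scatter) and the wide range reflects how little evidence there is. Compound 3 is estimated at 10000 nM within an expected range of 3000 nM to 33000 nM on this read-out.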

Compound 3, concentration for 50% growth inhibition: 12500 nM
Estimate against measurement, compound 3: 1.3-fold (0.10 log units) below; the range from low to high includes it.
By their numbers in this assay, from the lowest: compounds 3 and 2 (each within the scatter of the next); then compound 1.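

In this assay, for the compounds shown here, compound 2 and compound 3 give the first comparison in which only one place differs, and the step reads a 1.0-fold lower number from compound 2 to compound 3 (0.01 log units; within the scatter) when 3-isopropylphenyl takes the place of 4-methoxybenzyl on this nitrogen. At this position, the two groups cannot be told apart in this test, even though the oxygen of 4-methoxybenzyl is absent from 3-isopropylphenyl and both have the same count of heavy atoms and one six-membered aromatic ring of carbon only. No supporting measurement bears on this result, so it cannot be said why the two compounds read alike.

Going by these compounds, it remains open whether this nitrogen would give a similar reading with a very different group, such as one carrying an amine or a carboxylic acid, or a longer chain in place of either aromatic group. Compound 1 differs from compound 2 and compound 3 in more than one place, so the gap between its number and theirs cannot be assigned to any single part of the structure.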